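The compounds below may be only part of what the source reports. "The series", "measured", "known", "first", "only" and "open" are said of these compounds alone.

Measured so far:

Compound 1, `COc1cc2c(=O)c(C(=O)c3ccc(C)cc3)cn(Cc3ccc(S(N)(=O)=O)cc3)c2cc1OC`: > 25000 nM
Compound 2, `COc1cc2c(=O)c(S(=O)(=O)CCc3ccc(Cl)cc3)cn(Cc3ccccc3)c2cc1OC`: "not active" (no number reported)
Compound 3, `CN1CCN(c2cc3c(cc2F)c(=O)c(NC(=O)NCc2ccc(Cl)cc2)cn3Cc2ccc(Cl)cc2)CC1`: "not active" (no number reported)

In an ADME assay on Huh-7 cells (Homo sapiens) for cytotoxicity (a lower number here means a stronger inhibitor of growth, a higher number a weaker inhibitor of growth), compound 1 gives > 25000 nM, which is a limit of the assay and not a number. Compound 2 and compound 3 are recorded as inactive without any number, so among the three entries there is no single measured value to compare against, only (the limit of > 25000 nM in this assay, at which 1 of the 3 values shown sits).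

The next compound, compound 4, `COc1cc2c(=O)c(C(=O)c3ccc(C)cc3)cn(Cc3ccccc3)c2cc1OC`, differs from compound 1 in one place: hydrogen in place of sulfamoyl on an aromatic carbon. Among the compounds with values here, no step between two measured compounds is known here, so the size of this change in this assay cannot be read from data. The expectation is for no step beyond the scatter, in no particular direction, since every entry so far shows weak or no inhibition of growth. The step of a number no higher from compound 1 to compound 4 (the limit leaves the size open) is therefore expected to stay within the scatter. Compound 4 is expected to give 25000 nM, with a range from 10000 nM to 100000 nM, and most likely again only a limit.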

Compound 4, concentration for 50% growth inhibition: "not active" (no number reported)
The entry for compound 4 holds no number; the estimate stays without a comparison.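

No step from compound 1 to compound 4 can be read, because neither entry holds a single number: the limit of > 25000 nM in this assay, at which 1 of the 4 values shown sits.

The compounds shown leave open how far, if at all, going from 4-sulfamoylbenzyl to benzyl shifts growth inhibition in this assay and at what concentration any of them would inhibit growth.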